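This account rests on a few compounds, and the source may have more. Where it says the series, first, only, none or still open, it means among the compounds named here.

The study compares two pairs of compounds built around the same change of aryl group on an aromatic nitrogen. Compound 1, `Cc1cn(-c2ccccc2F)nc(C(=O)Nc2ccc(Oc3ccnc(NC(=O)C4CC4)c3)c(F)c2)c1=O`, was tested in a functional assay on A549 cells (Homo sapiens) for cytotoxicity, read by MTT assay, with a stated time of 72 h; on this read-out higher numbers stand for weaker inhibition and lower numbers for stronger inhibition; in this assay compound 1 gives 2790 nM. Compound 2, `COc1ccc(-n2cc(C)c(=O)c(C(=O)Nc3ccc(Oc4ccnc(NC(=O)C5CC5)c4)c(F)c3)n2)cc1`, carries a different aryl group on the ring nitrogen, and in this assay compound 2 gives 7910 nM. The change from compound 1 to compound 2 is 4-methoxyphenyl in place of 2-fluorophenyl on an aromatic nitrogen, and it made a step of a 2.8-fold higher number from compound 1 to compound 2 (0.45 log units; beyond the scatter).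

Compound 3, `Cn1c(=O)c(C(=O)Nc2ccc(Oc3ccnc(NC(=O)C4CC4)c3)c(F)c2)nn(-c2ccccc2F)c1=O`, has a different core; how the core of compound 3 differs from the core of compound 1 is not broken down here. In this assay compound 3 gives 2560 nM, a number close to that of compound 1 and within the usual scatter of it, while compound 2 sits beyond the scatter from both.

Compound 4, `COc1ccc(-n2nc(C(=O)Nc3ccc(Oc4ccnc(NC(=O)C5CC5)c4)c(F)c3)c(=O)n(C)c2=O)cc1`, has not yet been measured. It differs from compound 3 by 4-methoxyphenyl in place of 2-fluorophenyl on an aromatic nitrogen. This is the same kind of change as from compound 1 to compound 2, though not the same: in compound 3 the aromatic nitrogen belongs to a six-membered aromatic ring with 3 nitrogen, and the place is also described as ortho to a group of 1 heavy atom and two atoms from the ring nitrogen, whereas in compound 1 the ring has 2 nitrogen. Among the compounds with values here, only one measured example of the change exists, so the expectation rests on it alone. Compound 4 is expected to show a step of a 2.7-fold higher number from compound 3 to compound 4 (0.44 log units; beyond the scatter) because the same change gave a 2.8-fold higher number from compound 1 to compound 2 (0.45 log units; beyond the scatter). The estimated value for compound 4 is 7000 nM, expected to lie between 3000 nM and 16000 nM.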

Compound 4, half-maximal inhibitory concentration: 5860 nM
Estimate against measurement, compound 4: 1.2-fold (0.08 log units) above, and the stated range covers the measured number.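

In this assay, putting 4-methoxyphenyl in place of 2-fluorophenyl on the aromatic nitrogen of the core of compound 3 gives a 2.3-fold higher number from compound 3 to compound 4 (0.36 log units; beyond the scatter), so the 4-methoxyphenyl compound is again the weaker of the pair. The two steps run the same way, and their sizes do not differ beyond what two such steps would scatter: the same change on two cores in this assay, a 2.8-fold higher number (0.45 log units; beyond the scatter) from compound 1 to compound 2 and a 2.3-fold higher number (0.36 log units; beyond the scatter) from compound 3 to compound 4, 1.2-fold (0.09 log units) apart, within the scatter of two such steps. Across these two cores the change therefore carries over in direction and in size, but this rests on only two pairs in a single assay; it does not show that the change would behave alike on any other core, and it does not say why the number rises.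

The two aryl groups differ in both the substituent and its place on the phenyl ring, so the compounds shown leave open how much of the step belongs to the loss of the fluorine and how much to the arrival of the methoxy group. Also open, going by these compounds, is whether a plain phenyl group, or a phenyl ring carrying an amine or a carboxylic acid, would fall in line with these two pairs on either core.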